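Swapping a pyridine for a diol on the triazole nitrogen

The source may report more compounds than this note shows. Statements on the series, on what has been measured and on what is new or still open speak of the compounds shown alone.

Three compounds share one core and differ only in the group attached to a ring nitrogen of the five-membered ring. In a functional assay on the whole organism (strain Albino Wistar) for inhibition, with Rattus norvegicus as the target, read by paw edema, with stated times of 1 h and 5 h, at a dose of 10 mg/kg by the oral route (on this read-out higher numbers stand for more inhibition at the one dose given (going by the name of the read-out) and lower numbers for less inhibition), compound 1 `Clc1ccccc1-n1cc(CSc2nc3ccccc3s2)nn1` gives 78.1%. Compound 2 `Cc1ccccc1-n1cc(CSc2nc3ccccc3s2)nn1` gives 43.4%, and compound 3 `c1cncc(-n2cc(CSc3nc4ccccc4s3)nn2)c1` gives 56%, which places compound 3 second highest of the three, with compound 2 nearest and compound 1 furthest away.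

Compound 4 `OCC(O)Cn1cc(CSc2nc3ccccc3s2)nn1` is the next compound to be tested; the change from compound 3 is 2,3-dihydroxypropyl in place of pyridin-3-yl on an aromatic nitrogen.

Two measured steps change the group on the same aromatic nitrogen: a number 22.1 percentage points lower from compound 1 to compound 3 (beyond the scatter) and a number 12.6 percentage points higher from compound 2 to compound 3 (beyond the scatter). The third step, a number 34.7 percentage points lower from compound 1 to compound 2 (beyond the scatter), alters an aromatic carbon instead and bears less directly. Together they show that this position moves the read-out by amounts well beyond the scatter, in either direction. Among the measured compounds shown here, none of the measured groups is a chain, so the step to compound 4 is a larger departure than any seen so far, and its direction cannot be read from the data; a modest fall is the more cautious expectation. For compound 4 the expected value is 45%, with a likely range from 25% to 65%. That estimate corresponds to an expected step of a number 11 percentage points lower from compound 3 to compound 4 (beyond the scatter).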

Compound 4, a percentage reported as inhibition, in the whole organism at one dose (the size of the read-out at that dose, not a potency): 52.8%
Compound 4: the middle estimate sits 7.8 percentage points below what was measured; the range from low to high includes it.
By their numbers in this assay, from the lowest: compounds 2, 4 and 3 (each within the scatter of the next, the first and the last beyond it); then compound 1.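

In this assay, the open chain 2,3-dihydroxypropyl, which has no ring, can stand on this aromatic nitrogen in place of pyridin-3-yl, with a number 3.2 percentage points lower from compound 3 to compound 4 (within the scatter), so among these compounds a read-out of this size does not depend on an aromatic ring at this position. Set against 2-methylphenyl, the chain gives a number 9.4 percentage points higher from compound 2 to compound 4 (within the scatter), even though those two ring groups lie beyond the scatter of each other, while 2-chlorophenyl stays clearly apart from the chain, with a number 25.3 percentage points lower from compound 1 to compound 4 (beyond the scatter), and so remains the one group here that separates from all the others. No measurement is available that would explain why groups of such different shape give such close numbers.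

The compounds shown leave open whether the two hydroxyl groups of the chain contribute anything, which a plain propyl chain, or a longer chain ending in an amine or a carboxylic acid, could begin to test. They also leave open whether the high number of the 2-chlorophenyl compound extends to related rings such as 2-fluorophenyl or 2-bromophenyl.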